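A few compounds are considered here, and "the series" means these few. Any claim that something is new, unique, unknown or untested is made for them only; others in the source may bear on it.

Measured so far in a functional assay on SK-OV-3 cells (Homo sapiens) for cytotoxicity, read by spectrophotometry, with a stated time of 72 h; on this read-out higher numbers stand for weaker inhibition and lower numbers for stronger inhibition:
- compound 1, `COc1ccc(-c2cccc(=O)n2-c2cc(OC)c(OC)c(OC)c2)cc1`: < 10 nM
- compound 2, `COc1ccc(-c2cccc(=O)n2-c2cc(OC)c(OC)c(OC)c2)cc1OC`: 545 nM
- compound 3, `COc1ccc(-n2c(-c3cc(OC)c(OC)c(OC)c3)cccc2=O)cc1`: 1540 nM

Among the measured compounds shown here, the value of compound 1 is a limit of this assay, not a number; it is the single value sitting at the limit of < 10 nM in this assay, at which 1 of the 3 values shown sits. Compound 2 differs from compound 1 by one change, (methoxy in place of hydrogen on an aromatic carbon), and the step is an at least 54-fold higher number from compound 1 to compound 2 (1.73 log units; beyond the scatter). Since the starting point is a limit, the true size of that step is not known, only its floor.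

Compound 3 has the same atoms as compound 1, joined differently; the difference between the two cores is not broken down here. In this assay compound 3 gives 1540 nM, the highest number of the two numbers measured, with compound 2 as its nearest neighbour.

Compound 4, `COc1ccc(-n2c(-c3cc(OC)c(OC)c(OC)c3)cccc2=O)cc1OC`, is not yet measured. It stands to compound 3 as compound 2 stands to compound 1: the change is methoxy in place of hydrogen on an aromatic carbon, the same change as before, with the surroundings of the place described in the same words. The expected step is a 9.7-fold higher number from compound 3 to compound 4 (0.99 log units; beyond the scatter), set beside the measured at least 54-fold higher number from compound 1 to compound 2 (1.73 log units; beyond the scatter). It rests on that single step and on compound 3 starting from 1540 nM. It also rests on the fact that the measured step is a floor set by a limit. Compound 4 is therefore estimated at 15000 nM, with a range of 3500 nM to 70000 nM, and a fair chance that this assay reports only a limit for it.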

Compound 4, half-maximal inhibitory concentration: 14300 nM
Compound 4: the middle estimate sits 1.0-fold (0.02 log units) above what was measured; measured number inside the range.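

In this assay, methoxy in place of hydrogen on an aromatic carbon gives a higher number on both cores, and on the core of compound 3 the step is a 9.3-fold higher number from compound 3 to compound 4 (0.97 log units; beyond the scatter), so the direction of the change carries over between these two cores. The size of the step does not carry over unchanged: the same change on two cores in this assay, an at least 54-fold higher number (1.73 log units; beyond the scatter) from compound 1 to compound 2 and a 9.3-fold higher number (0.97 log units; beyond the scatter) from compound 3 to compound 4, at least 5.8-fold (0.76 log units) apart, beyond the scatter of two such steps Compound 1 stands at < 10 nM, a limit and not a number, so the gap between the two steps is known only as a floor, and two cores give no rule for any further core.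

The compounds shown have only hydrogen or methoxy at this place, ortho to a methoxy group, so it remains open how a hydroxyl, an ethoxy chain or an amine would behave there on either core. Also open, going by these compounds, is how far the numbers would move if a hydroxyl or an amine took the place of one of the other methoxy groups, and whether the gap between the two cores would then hold.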